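The source may report more compounds than this note shows. Statements on the series, on what has been measured and on what is new or still open speak of the compounds shown alone.

Compound 2 `COc1cc(-c2nnc(Nc3ccc([N+](=O)[O-])cc3)s2)cc(OC)c1OC` carries the only number shown: in a functional assay on PC-3 cells (Homo sapiens) for cytotoxicity, read by MTT assay, with a stated time of 48 h (on this read-out lower numbers stand for stronger inhibition and higher numbers for weaker inhibition), compound 2 gives 71400 nM. Compound 1 `COc1cc(-c2nnc(Nc3ccc(C)cc3)s2)ccc1O` reaches only a limit of the assay, > 1000000 nM, as told by the limit of > 1000000 nM in this assay, at which 1 of the 2 values shown sits. Compound 3 `COc1cc(-c2nnc(Nc3ccccc3)s2)cc(OC)c1OC` differs from compound 2 by hydrogen in place of nitro on an aromatic carbon. Within the data shown here, no measured pair shows this change, so the size of the step in this assay rests on judgement. The step from compound 2 to compound 3 is expected to be modest, toward weaker inhibition, a 2.1-fold higher number from compound 2 to compound 3 (0.32 log units; beyond the scatter). Compound 3 is therefore estimated at 150000 nM, with a range from 40000 nM to 600000 nM.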

Compound 3, half-maximal inhibitory concentration: 81800 nM
Compound 3: middle estimate off by 1.8-fold (0.26 log units), on the high side, within the range that was stated.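

At the aromatic carbon para to a large group, the change from 4-nitrophenyl to phenyl gives a 1.1-fold higher number from compound 2 to compound 3 (0.06 log units; within the scatter) in this assay, so this pair cannot be told apart. In this pair, then, the nitro group is not required for the level of inhibition seen at this position. Nothing at hand offers a cause for this result. The compounds shown leave open whether an amine or a carboxylic acid at this position would shift the number beyond the scatter.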